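This account rests on a few compounds, and the source may have more. Where it says the series, first, only, none or still open, it means among the compounds named here.

Compound 2 `COC(=O)OCC(CO)CCn1cnc2cnc(N)nc21` and compound 1 `CCCOC(=O)OCC(CO)CCn1cnc2cnc(N)nc21` share one core and differ in a single place. In a functional assay on Vero cells (Chlorocebus sabaeus) for cytotoxicity (a higher number here means that more compound is tolerated, a lower number that less compound is tolerated), compound 2 gives > 500000 nM, which is a limit of the assay rather than a number. In this assay compound 1 likewise gives > 500000 nM, again a limit. Because both values sit at the limit of > 500000 nM in this assay, at which 2 of the 2 values shown sit, the step that the two limits leave unreadable from compound 1 to compound 2 cannot be read, so no difference between these two compounds can be sized. Compound 3 `CCOC(=O)OCC(CO)CCn1cnc2cnc(N)nc21` is not yet measured. It differs from compound 2 by methyl in place of hydrogen on a saturated chain carbon bound to an oxygen next to a carbonyl group, which, cut one bond further out, reads methoxycarbonyl to ethoxycarbonyl. Going by the values given here, the only measured step, from compound 1 to compound 2, touches the same place but is unreadable, so no change beyond the scatter is expected in this assay. Compound 3 is therefore expected to give 800000 nM, within 400000 nM to 2000000 nM, and most likely reported only as a limit. The expected step that the limit leaves unreadable from compound 2 to compound 3 is essentially none.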

Compound 3, half-maximal cytotoxic concentration: > 500000 nM
Compound 3 gave a limit, no number; the forecaster's own chance of this, stated with the estimate: 90%; the middle value does not contradict the limit.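

Going by these compounds alone, compound 1, compound 2 and compound 3 all give only a limit in this assay, so no step among them can be read: the limit of > 500000 nM in this assay, at which 3 of the 3 values shown sit. The compounds shown leave open the concentration at which any of the three harms these cells, and whether the single changes between them alter it.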